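Chain-end heteroaryl swap on two cores: lipophilicity notes

A few compounds are considered here, and "the series" means these few. Any claim that something is new, unique, unknown or untested is made for them only; others in the source may bear on it.

Measured in a physicochemical assay for lipophilicity, read by HPLC; on this read-out lower numbers stand for lower lipophilicity and higher numbers for higher lipophilicity:
compound 1 `Cc1cc(CCCCCOc2c(Cl)cc(C3=NCCO3)cc2Cl)on1`, 4.6
compound 2 `Cc1cc(CCCCCOc2c(C)cc(-c3nnn(C)n3)cc2C)on1`, 3.6
compound 3 `CC(=O)c1ccc(CCCCCOc2c(Cl)cc(C3=NCCO3)cc2Cl)o1`, 4.6

Compound 1 and compound 3 share a core and differ only by 5-acetylfuran-2-yl in place of 3-methyl-1,2-oxazol-5-yl on a saturated chain carbon, five bonds along the chain from an oxygen on an aromatic ring; this gave no change at the digits printed from compound 1 to compound 3 (within the scatter). Compound 2 stands lowest of the three in this assay, beyond the scatter from both compound 1 and compound 3. How the core of compound 2 differs from the core of compound 1 is not broken down here.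

Compound 4 `CC(=O)c1ccc(CCCCCOc2c(C)cc(-c3nnn(C)n3)cc2C)o1` is not yet measured. It carries the same change as before, (5-acetylfuran-2-yl in place of 3-methyl-1,2-oxazol-5-yl on a saturated chain carbon, five bonds along the chain from an oxygen on an aromatic ring), with the place described in the same words. Because the earlier change gave no change at the digits printed from compound 1 to compound 3 (within the scatter), the step of no change at the digits printed from compound 2 to compound 4 (within the scatter) is expected to be about as small. Compound 4 is therefore estimated at 3.6 in this assay, expected between 3.2 and 4.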

Compound 4, partition coefficient: 3.7
For compound 4 the middle estimate is 0.10 log units below the measured one; the range from low to high includes it.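

In this assay, 5-acetylfuran-2-yl in place of 3-methyl-1,2-oxazol-5-yl on the chain gives a number 0.10 log units higher from compound 2 to compound 4 (within the scatter), matching no change at the digits printed from compound 1 to compound 3 (within the scatter) on the other core. The change therefore carries across these two cores with no step beyond the scatter, but two cores and one read-out do not show that it would carry to any further core or to another kind of measurement. Nothing available here bears on the reason for this agreement.

The compounds shown leave open whether the same holds for other groups at the chain end, such as an amine or a carboxylic acid. They also leave open whether it holds on a longer chain.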